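Dimethylamino for methoxy on the pyridine of a thiazole acid

The source may hold more compounds than are shown below. What is called first, only, known or untested is meant among the compounds shown, and "the series" means these compounds.

Of the compounds shown here, three sharing one core have been measured in an in vitro functional assay on HEK285-7 cells for antagonist activity at prostaglandin D2 receptor 2 (Homo sapiens), read by BRET and beta-arrestin recruitment; on this read-out higher numbers stand for weaker inhibition and lower numbers for stronger inhibition. Compound 1 `NS(=O)(=O)c1cccc(-c2nc(C(c3ccc(F)cc3)c3ccc(F)cc3)sc2CC(=O)O)c1` gives 710 nM, compound 2 `O=C(O)Cc1sc(C(c2ccc(F)cc2)c2ccc(F)cc2)nc1-c1ccco1` gives 140 nM, and compound 3 `COc1cc(-c2nc(C(c3ccc(F)cc3)c3ccc(F)cc3)sc2CC(=O)O)ccn1` gives 380 nM. Compound 3 thus holds the second highest of the three numbers: its nearest neighbour is compound 1, since a 1.9-fold lower number from compound 1 to compound 3 (0.27 log units; within the scatter), and its furthest is compound 2, since a 2.7-fold higher number from compound 2 to compound 3 (0.43 log units; beyond the scatter). The largest step seen so far is a 5.1-fold lower number from compound 1 to compound 2 (0.71 log units; beyond the scatter).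

Compound 4 `CN(C)c1cc(-c2nc(C(c3ccc(F)cc3)c3ccc(F)cc3)sc2CC(=O)O)ccn1` differs from compound 3 in one place: dimethylamino in place of methoxy on an aromatic carbon. For the measured compounds named here, every measured step so far exchanges the whole aryl group on that carbon of the core; none of them alters a substituent on the 2-methoxypyridin-4-yl group itself, so no measured step bears directly on this change. The three steps show that the aryl position tolerates quite different groups with modest consequences, and a change confined to one small group on that ring is therefore expected to move this assay little, most likely within the scatter and in no settled direction.

Compound 4 is accordingly estimated at 330 nM, within 130 nM to 900 nM, which as a step means a 1.2-fold lower number from compound 3 to compound 4 (0.06 log units; within the scatter).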

Compound 4, half-maximal inhibitory concentration: > 100000 nM
Compound 4 was reported as a limit; the forecaster's own chance of this, stated with the estimate: 3%; middle value at least 300-fold (2.48 log units) away from the limit.
By their numbers in this assay, from the lowest: compound 2; then compounds 3 and 1 (each within the scatter of the next). At a limit, above all of these: compound 4.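

In this assay, compound 4 is reported only as a limit, not as a number: the limit of > 100000 nM in this assay, at which 1 of the 4 values shown sits. For the compounds shown here, exchanging methoxy for dimethylamino on an aromatic carbon next to the ring nitrogen gives an at least 260-fold higher number from compound 3 to compound 4 (2.42 log units; beyond the scatter), a far larger step than the biggest one among the earlier compounds, a 5.1-fold lower number from compound 1 to compound 2 (0.71 log units; beyond the scatter), so a change in one small group on this pyridine can outweigh exchanging the whole aryl group at this position of the shared core. The steps of an at least 710-fold higher number from compound 2 to compound 4 (2.85 log units; beyond the scatter) and an at least 140-fold higher number from compound 1 to compound 4 (2.14 log units; beyond the scatter) set 2-(dimethylamino)pyridin-4-yl apart from all three other aryl groups, so the tolerance suggested by furan-2-yl, 3-sulfamoylphenyl and 2-methoxypyridin-4-yl does not extend to it.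

The compounds shown leave open whether this sharp loss belongs to dimethylamino alone or would also follow from a primary amine, a methylamino group or a ring amine such as azetidine on the same carbon. They also leave open whether an ethoxy group would stay close to methoxy, and whether dimethylamino on a phenyl ring in place of the pyridine would have the same consequence.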